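This account rests on a few compounds, and the source may have more. Where it says the series, first, only, none or still open, it means among the compounds named here.

Measured so far:
compound 1, `CCCCCCCCCCCCCCNC(=O)[C@@H](NC(=O)c1cccs1)[C@@H](C)O`: 78400 nM
compound 2, `CCCCCCCCCCCCCCNC(=O)[C@@H](NC(=O)c1nccc2ccccc12)[C@@H](C)O`: 30400 nM

In a functional assay on SW-620 cells (Homo sapiens) for cytotoxicity, read by MTT assay, with a stated time of 48 h (a higher number here means a weaker inhibitor, a lower number a stronger inhibitor), compound 2 stands at the lower of the two numbers; its nearest neighbour is compound 1, from which it is separated by a 2.6-fold lower number from compound 1 to compound 2 (0.41 log units; beyond the scatter), a modest step beyond the scatter, brought about by isoquinolin-1-yl in place of thiophen-2-yl on a carbonyl carbon.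

Compound 3, `C/C=C/C=C/C(=O)N[C@H](C(=O)NCCCCCCCCCCCCCC)[C@@H](C)O`, has not yet been measured. It differs from compound 2 by penta-1,3-dien-1-yl in place of isoquinolin-1-yl on a carbonyl carbon. Among the measured compounds shown here, only one measured step touches this carbonyl substituent, the one from compound 1 to compound 2, and it swaps one aromatic ring system for another; nothing measured shows what an open-chain diene does at this position. The ring system that gave compound 2 its lower number is removed in compound 3, so a step back towards a higher number in this assay is expected, of about a 2.0-fold higher number from compound 2 to compound 3 (0.30 log units; within the scatter), though with wide uncertainty. Compound 3 is therefore estimated at 60000 nM, within a range from 20000 nM to 180000 nM.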

Compound 3, half-maximal inhibitory concentration: 200000 nM
The estimate for compound 3 lay 3.3-fold (0.52 log units) below the measured number; measured number outside the range, above it.
By their numbers in this assay, from the lowest: compound 2; then compound 1; then compound 3.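

In this assay, the open-chain penta-1,3-dien-1-yl group does more than lose what isoquinolin-1-yl gained, as the change gives a 6.6-fold higher number from compound 2 to compound 3 (0.82 log units; beyond the scatter) and also goes past thiophen-2-yl, with a 2.6-fold higher number from compound 1 to compound 3 (0.41 log units; beyond the scatter) on the same scale. This carbonyl substituent can therefore move the number in either direction from thiophen-2-yl, and in these three compounds the two groups with an aromatic ring both lie lower than the group with no ring. Nothing at hand accounts for this order.

The three compounds do not separate the presence of a ring from the size of the group. A saturated pentyl chain or a plain phenyl ring at this place would help to tell whether the double bonds, the ring or the ring nitrogen tracks the number.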